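Cytotoxicity Across Three Benzyl Variants

The compounds below may be only part of what the source reports. "The series", "measured", "known", "first", "only" and "open" are said of these compounds alone.

Three compounds share one core and differ only in the benzyl group. In an ADME assay on MT2 cells (Homo sapiens) for cytotoxicity, read by XTT assay, with a stated time of 4 days (on this read-out lower numbers stand for higher toxicity in this test and higher numbers for lower toxicity in this test), compound 1 `Cc1cc(/C=C2\SC(=S)N(Cc3ccc(C(F)(F)F)cc3)C2=O)c(C)n1-c1ccc(O)c(C(=O)O)c1` gives 45900 nM, compound 2 `COC(=O)c1ccc(CN2C(=O)/C(=C/c3cc(C)n(-c4ccc(O)c(C(=O)O)c4)c3C)SC2=S)cc1` gives 36900 nM, and compound 3 `Cc1cc(/C=C2\SC(=S)N(Cc3ccc(C(C)(C)C)cc3)C2=O)c(C)n1-c1ccc(O)c(C(=O)O)c1` gives 55200 nM. Compound 3 sits within the scatter of both others: a 1.2-fold higher number from compound 1 to compound 3 (0.08 log units; within the scatter) and a 1.5-fold higher number from compound 2 to compound 3 (0.17 log units; within the scatter). Compound 4 `Cc1cc(/C=C2\SC(=S)N(Cc3cccc(C(F)(F)F)c3)C2=O)c(C)n1-c1ccc(O)c(C(=O)O)c1` carries 3-(trifluoromethyl)phenyl in place of 4-(tert-butyl)phenyl on a saturated chain carbon bound to an amide-type nitrogen in a ring. Within the data shown here, the step from compound 1 to compound 3 bears on this change, as it exchanged the same two groups and stayed within the scatter; no measured step compares the 3-(trifluoromethyl)phenyl group with any other. The step from compound 3 to compound 4 is therefore expected to be a 1.2-fold lower number from compound 3 to compound 4 (0.08 log units; within the scatter), nothing beyond the scatter. Compound 4 is estimated at 46000 nM, with a range from 25000 nM to 85000 nM.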

Compound 4, half-maximal cytotoxic concentration: 26300 nM
Compound 4: middle estimate off by 1.7-fold (0.24 log units), on the high side; measured number inside the range.
By their numbers in this assay, from the lowest: compounds 4, 2, 1 and 3 (each within the scatter of the next, the first and the last beyond it).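

In this assay, this position gives its first step beyond the scatter (a 2.1-fold lower number from compound 3 to compound 4 (0.32 log units; beyond the scatter)), with 3-(trifluoromethyl)phenyl in place of 4-(tert-butyl)phenyl. The other two steps stay within the scatter (a 1.7-fold lower number from compound 1 to compound 4 (0.24 log units; within the scatter); a 1.4-fold lower number from compound 2 to compound 4 (0.15 log units; within the scatter)), so exchanging 4-(trifluoromethyl)phenyl or 4-(methoxycarbonyl)phenyl for 3-(trifluoromethyl)phenyl shows no clear change. Among these compounds, nothing available explains the one modest step. The compounds shown leave open how a ring carrying an amine or a carboxylic acid would read here. They also leave open whether a longer chain would shift the number.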